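The source may hold more compounds than are shown below. What is called first, only, known or untested is meant among the compounds shown, and "the series" means these compounds.

Compound 2 `C[C@H](NC(=O)c1c(-c2ccccc2)nnn1Cc1ccc(F)c(F)c1)c1ccc(C(=O)O)cc1` stands lowest of the two numbers in a functional assay on CHO cells for antagonist activity at prostaglandin E2 receptor EP4 subtype (Homo sapiens), read by calcium flux, with a stated time of 15 min (a higher number here means a weaker inhibitor, a lower number a stronger inhibitor), where compound 2 gives 148 nM; its nearest neighbour is compound 1 `C[C@H](NC(=O)c1c(-c2ccccc2)nnn1Cc1ccccc1)c1ccc(C(=O)O)cc1`, which in this assay gives 647 nM. Compound 3 `COc1ccc(Cn2nnc(-c3ccccc3)c2C(=O)N[C@@H](C)c2ccc(C(=O)O)cc2)cc1` differs from compound 2 by 4-methoxyphenyl in place of 3,4-difluorophenyl on a saturated chain carbon bound to an aromatic nitrogen. Among the measured compounds shown here, the only measured step at this place, a 4.4-fold lower number from compound 1 to compound 2 (0.64 log units; beyond the scatter), shows that the ring on that carbon matters, but nothing measured tests 4-methoxyphenyl there. Compound 3 is therefore expected to fall between the two measured values, with the step of a 2.4-fold higher number from compound 2 to compound 3 (0.37 log units; beyond the scatter) as the estimate. The estimated value of compound 3 in this assay is 350 nM, within 120 nM to 1000 nM.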

Compound 3, half-maximal inhibitory concentration: 9.3 nM
Compound 3: the middle estimate sits 38-fold (1.58 log units) above what was measured, and the stated range ends above it.
By their numbers in this assay, from the lowest: compound 3; then compound 2; then compound 1.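

In this assay, the substituents on the ring at this saturated chain carbon bound to an aromatic nitrogen prove decisive: 4-methoxyphenyl in place of 3,4-difluorophenyl gives a 16-fold lower number from compound 2 to compound 3 (1.20 log units; beyond the scatter), a larger step than any seen before. Methoxy in place of hydrogen on an aromatic carbon gives a 70-fold lower number from compound 1 to compound 3 (1.84 log units; beyond the scatter), so one group there outdoes the two fluorines. Nothing available explains this difference. From the compounds shown here alone, whether 4-hydroxyphenyl or 4-ethoxyphenyl would keep the number this low remains open, as does whether 4-methylphenyl would.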